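Chloro to bromo, compound 3 to compound 4

The source may hold more compounds than are shown below. What is called first, only, known or untested is meant among the compounds shown, and "the series" means these compounds.

Compound 1, `Fc1ccc(Nc2nc(-c3cccc(F)c3)nc3ccc(F)cc23)cc1`: in a functional assay on HL-60 cells (Homo sapiens) for cytotoxicity, read by MTT assay, with a stated time of 48 h (on this read-out lower numbers stand for stronger inhibition and higher numbers for weaker inhibition), compound 1 gives > 50000 nM, which is a limit of the assay and not a number.
Compound 2, `Fc1cccc(-c2nc(Nc3ccccc3F)c3cc(F)ccc3n2)c1`: in this assay compound 2 gives > 50000 nM, again a limit.
Compound 3, `Fc1cccc(-c2nc(Nc3cccc(Cl)c3)c3cc(F)ccc3n2)c1`: in this assay compound 3 gives > 50000 nM, also a limit.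

Compound 3 therefore stands at the limit of this assay, together with every other measured member of the series (the limit of > 50000 nM in this assay, at which 3 of the 3 values shown sit). The three steps among the measured compounds, a step that the two limits leave unreadable from compound 1 to compound 2, a step that the two limits leave unreadable from compound 1 to compound 3 and a step that the two limits leave unreadable from compound 2 to compound 3, each exchange the group on a nitrogen on an aromatic ring, and none of them can be read, as both ends sit at the limit.

Compound 4, `Fc1cccc(-c2nc(Nc3cccc(Br)c3)c3cc(F)ccc3n2)c1`, differs from compound 3 by bromo in place of chloro on an aromatic carbon. Within the data shown here, no measured step exchanges one halogen for another at this place, so no step in this assay bears directly on the change; the measured steps only show that the series has not yet moved off the limit. Compound 4 is accordingly expected to remain at or beyond the limit, with an estimate of 60000 nM and a range from 25000 nM to 200000 nM. The expected step that the limit leaves unreadable from compound 3 to compound 4 is an estimate only, taken as none beyond the scatter, and cannot be checked against a limit.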

Compound 4, half-maximal inhibitory concentration: > 50000 nM
Compound 4 gave a limit, no number; the forecaster's own chance of this, stated with the estimate: 85%; the middle value does not contradict the limit.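

In this assay compound 4 gives > 50000 nM, a limit and not a number. No new step can be read between compound 4 and compound 1, compound 2 or compound 3, because all four sit at the same limit: the limit of > 50000 nM in this assay, at which 4 of the 4 values shown sit.

The compounds shown leave open how bromo and chloro compare here, and what activity, if any, the shared core can reach in this assay.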